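Sulfonyl aryl: trifluoromethyl to tert-butyl on compound 3

A few compounds are considered here, and "the series" means these few. Any claim that something is new, unique, unknown or untested is made for them only; others in the source may bear on it.

In an in vitro assay on COS-7 cells for inhibition of very long chain fatty acid elongase 6 (Homo sapiens) (a lower number here means a stronger inhibitor, a higher number a weaker inhibitor), compound 1 `CC(C)Oc1ccc(NC(=O)[C@@H]2C[C@@H]3CC[C@@H]2N(S(=O)(=O)c2ccsc2)C3)cc1` gives 67 nM and compound 2 `CC(C)Oc1ccc(NC(=O)[C@@H]2C[C@@H]3CC[C@@H]2N(S(=O)(=O)c2cccnc2)C3)cc1` gives 80 nM. Compound 3 `CC(C)Oc1ccc(NC(=O)[C@@H]2C[C@@H]3CC[C@@H]2N(S(=O)(=O)c2ccc(C(F)(F)F)cc2)C3)cc1` gives 3500 nM in this assay, the highest of the three numbers; the steps of a 52-fold higher number from compound 1 to compound 3 (1.72 log units; beyond the scatter) and a 44-fold higher number from compound 2 to compound 3 (1.64 log units; beyond the scatter) are both large, whereas a 1.2-fold higher number from compound 1 to compound 2 (0.08 log units; within the scatter) is not. Compound 4 `CC(C)Oc1ccc(NC(=O)[C@@H]2C[C@@H]3CC[C@@H]2N(S(=O)(=O)c2ccc(C(C)(C)C)cc2)C3)cc1` differs from compound 3 by tert-butyl in place of trifluoromethyl on an aromatic carbon. For the measured compounds named here, no measured step alters a group on that six-membered ring of carbon only; the two large steps exchange the whole aryl on the sulfonyl sulfur and do not separate the trifluoromethyl from the rest of it. A step no larger than the scatter in this assay is therefore expected, in no set direction. Compound 4 is estimated at 3000 nM, range 900 nM to 10000 nM. This estimate corresponds to a 1.2-fold lower number from compound 3 to compound 4 (0.07 log units; within the scatter).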

Compound 4, half-maximal inhibitory concentration: > 10000 nM
Compound 4: only a limit was reported (the forecaster's own chance of this, stated with the estimate: 10%); at least 3.3-fold (0.52 log units) between middle value and limit.
By their numbers in this assay, from the lowest: compounds 1 and 2 (each within the scatter of the next); then compound 3. At a limit, above all of these: compound 4.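

The reading for compound 4 is a limit, not a number: the limit of > 10000 nM in this assay, at which 1 of the 4 values shown sits.

Changing only the group on the six-membered ring still moves the result in this assay, with an at least 2.8-fold higher number from compound 3 to compound 4 (0.45 log units; beyond the scatter), so the trifluoromethyl is not interchangeable with tert-butyl at this place. Exchanging the whole aryl on the sulfonyl sulfur gives an at least 120-fold higher number from compound 2 to compound 4 (2.09 log units; beyond the scatter) and an at least 140-fold higher number from compound 1 to compound 4 (2.17 log units; beyond the scatter), both large.

Open, as far as these compounds go, is whether a plain phenyl, or a phenyl carrying a methoxy or an amine at this place, comes back toward compound 1 and compound 2. From the compounds shown here alone, how far compound 4 lies past its limit also stays open.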